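Substituent variation on the aromatic ring of the urea series

The source may hold more compounds than are shown below. What is called first, only, known or untested is meant among the compounds shown, and "the series" means these compounds.

Within the data shown here, compound 3 `CC(=O)N[C@H]1/C(=N/NC(=O)Nc2ccccc2)O[C@H](CO)[C@@H](O)[C@@H]1O` gives 205 nM in an assay on isolated protein (Homo sapiens) for inhibition of HEXA/HEXB (Bos taurus), using a Dixon plot (a higher number here means a weaker inhibitor, a lower number a stronger inhibitor), the second highest of the three numbers so far. Compound 2 `CC(=O)N[C@H]1/C(=N/NC(=O)Nc2ccc(Cl)cc2)O[C@H](CO)[C@@H](O)[C@@H]1O` gives 170 nM, and a 1.2-fold higher number from compound 2 to compound 3 (0.08 log units; within the scatter). Compound 1 `COc1ccc(NC(=O)N/N=C2\O[C@H](CO)[C@@H](O)[C@H](O)[C@H]2NC(C)=O)cc1` gives 413 nM, and a 2.0-fold lower number from compound 1 to compound 3 (0.30 log units; within the scatter). Compound 4 `CC(=O)N[C@H]1/C(=N/NC(=O)Nc2ccc(C(F)(F)F)cc2)O[C@H](CO)[C@@H](O)[C@@H]1O` differs from compound 3 by trifluoromethyl in place of hydrogen on an aromatic carbon. Among the measured compounds shown here, the steps that bear on this change are those at the same aromatic carbon: a 2.4-fold lower number from compound 1 to compound 2 (0.39 log units; beyond the scatter), a 2.0-fold lower number from compound 1 to compound 3 (0.30 log units; within the scatter) and a 1.2-fold higher number from compound 2 to compound 3 (0.08 log units; within the scatter). Only the first of these lies beyond the scatter, and chloro gave a number within the scatter of hydrogen. For compound 4 no step beyond the scatter is therefore expected, a 1.2-fold lower number from compound 3 to compound 4 (0.08 log units; within the scatter). Compound 4 is estimated at 170 nM in this assay, with a range of 80 nM to 400 nM.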

Compound 4, inhibition constant: 125 nM
Compound 4: middle estimate off by 1.4-fold (0.13 log units), on the high side; low and high end bracket the measured number.
By their numbers in this assay, from the lowest: compounds 4, 2, 3 and 1 (each within the scatter of the next, the first and the last beyond it).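

At this aromatic carbon, para to a large group, trifluoromethyl does not separate from hydrogen (a 1.6-fold lower number from compound 3 to compound 4 (0.21 log units; within the scatter)) or from chloro (a 1.4-fold lower number from compound 2 to compound 4 (0.13 log units; within the scatter)) in this assay, so these three compounds form one group within the scatter. Methoxy is the only group that stands apart from trifluoromethyl (a 3.3-fold lower number from compound 1 to compound 4 (0.52 log units; beyond the scatter)), which adds a second step beyond the scatter to the one from methoxy to chloro. No measurement shown accounts for these steps.

As far as these compounds go, whether an amine or a carboxylic acid at this carbon would stay within that group remains open. So does whether trifluoromethyl or chloro would give similar numbers at other carbons of the ring.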